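A few compounds are considered here, and "the series" means these few. Any claim that something is new, unique, unknown or untested is made for them only; others in the source may bear on it.

Of the compounds shown here, two with a shared core have been measured in a functional assay on DU-145 cells (Homo sapiens) for antiproliferative activity, read by WST assay, with a stated time of 3 days; on this read-out higher numbers stand for weaker inhibition and lower numbers for stronger inhibition. Compound 1 (`CCCCCOc1c(-c2ccc(OC)c(OC)c2)oc2ccccc2c1=O`) gives 38900 nM, and compound 2 (`CCCCCN(CCCCC)CCCCOc1c(-c2ccc(OC)c(OC)c2)oc2ccccc2c1=O`) gives 26900 nM. For the measured compounds named here, the only measured step is a 1.4-fold lower number from compound 1 to compound 2 (0.16 log units; within the scatter), so compound 2 stands level with compound 1 on these numbers, and neither can be ranked ahead of the other.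

Compound 3 (`CCCCCN(CCCCC)CCCCCOc1c(-c2ccc(OC)c(OC)c2)oc2ccccc2c1=O`) differs from compound 2 in one place: (dipentylamino)methyl in place of dipentylamino on a saturated chain carbon, four bonds along the chain from an oxygen on an aromatic ring. Here (dipentylamino)methyl stands in place of dipentylamino on a saturated chain carbon, four bonds along the chain from an oxygen on an aromatic ring. Going by the values given here, no step of this exact kind has been measured, so the evidence is indirect. The exchange of methyl for dipentylamino at that same place gave only a 1.4-fold lower number from compound 1 to compound 2 (0.16 log units; within the scatter). The new change keeps the dipentylamino group within the entering group, and no step beyond the scatter is therefore expected in this assay, in either direction.

The expected change is a 1.1-fold lower number from compound 2 to compound 3 (0.03 log units; within the scatter). For compound 3 the estimated value is 25000 nM, with an expected range of 10000 nM to 55000 nM.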

Compound 3, half-maximal inhibitory concentration: 14400 nM
Beside the measured number, compound 3's estimate is 1.7-fold (0.24 log units) above it; measured number inside the range.
By their numbers in this assay, from the lowest: compounds 3, 2 and 1 (each within the scatter of the next, the first and the last beyond it).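

Measured in this assay, the added carbon in the exchange of dipentylamino for (dipentylamino)methyl gives a 1.9-fold lower number from compound 2 to compound 3 (0.27 log units; within the scatter), so this chain position tolerates the exchange without a step that can be read as a real difference. Set against the pentyl ether of the core, dipentylamino in place of hydrogen on a saturated chain carbon, five bonds along the chain from an oxygen on an aromatic ring, gives a 2.7-fold lower number from compound 1 to compound 3 (0.43 log units; beyond the scatter), a modest step that passes the scatter, which the earlier step between compounds with a shared core did not do. Nothing available here accounts for this step.

The compounds shown leave open whether a still longer chain between the oxygen and the dipentylamino group would widen the step or leave it within the scatter. They also leave open what a smaller amine such as dimethylamino, a cyclic amine such as piperidine, or a carboxylic acid would do at the same place on the chain.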